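Trimming the ester of a crown-ether growth inhibitor

The compounds below may be only part of what the source reports. "The series", "measured", "known", "first", "only" and "open" are said of these compounds alone.

In a functional assay on HBL-100 cells (Homo sapiens) for inhibition, read by sulforhodamine B assay, with a stated time of 48 h (on this read-out lower numbers stand for stronger inhibition of growth and higher numbers for weaker inhibition of growth), compound 1 `CC(C)=CC1C(C(=O)OCC2COCCOCCOCCOCCOCCO2)C1(C)C` gives 40000 nM. Compound 2 `O=C(CCCCCCCCCCOc1ccccc1)OCC1COCCOCCOCCOCCOCCO1` gives 20000 nM in this assay, and the two values lie within the usual scatter of each other, so compound 1 holds the higher of the two numbers without a meaningful gap to compound 2. Compound 3 `O=C(CCCCC1CCCCC1)OCC1COCCOCCOCCO1` sits at a limit of this assay, > 100000 nM, which is the limit described as the limit of > 100000 nM in this assay, at which 1 of the 3 values shown sits. Compound 4 `CC(=O)OCC1COCCOCCOCCOCCOCCO1` has not yet been measured in this assay. It differs from compound 1 by methyl in place of 2,2-dimethyl-3-(2-methylprop-1-en-1-yl)cyclopropyl on a carbonyl carbon. Among the compounds with values here, no measured pair differs in only one place, so the size of this step is uncertain; the expected step is a 2.5-fold higher number from compound 1 to compound 4 (0.40 log units; beyond the scatter), toward weaker growth inhibition. Compound 4 is therefore expected to give about 100000 nM in this assay, with a likely range from 30000 nM to 300000 nM.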

Compound 4, concentration for 50% growth inhibition: > 100000 nM
Compound 4 was reported as a limit (the forecaster's own chance of this, stated with the estimate: 55%); the middle value lies on the limit itself.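

Within the data shown here, compound 1 and compound 4 form the first pair that differs in one place, so this position on the carbonyl carbon can now be read. In this assay methyl in place of 2,2-dimethyl-3-(2-methylprop-1-en-1-yl)cyclopropyl gives an at least 2.5-fold higher number from compound 1 to compound 4 (0.39 log units; beyond the scatter) toward weaker growth inhibition. Compound 4 stands at > 100000 nM as a limit of the assay, not a number, and it is not alone there: the limit of > 100000 nM in this assay, at which 2 of the 4 values shown sit.

The compounds shown leave open which part of the departing group matters, the three-membered ring or the double bond. An unsubstituted cyclopropyl or a phenyl on the same carbonyl carbon would help to separate these.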